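Chloro to Methoxy on the Shared Core: Expected Tolerance

This account rests on a few compounds, and the source may have more. Where it says the series, first, only, none or still open, it means among the compounds named here.

Compound 1 `O=C(CSc1c[nH]c2ccc(Cl)cc12)Nc1ccc(Cl)c(Cl)c1` was tested in an ADME assay on HEK-293T cells (Homo sapiens) for cytotoxicity, read by CCK-8 assay, with a stated time of 48 h (a lower number here means that less compound is tolerated, a higher number that more compound is tolerated), where compound 1 gives 42700 nM. Among the numbers shown this is the only plain value. Compound 2 `Cn1cc(S(=O)(=O)CC(=O)Nc2cc(Cl)ccc2Cl)c2ccccc21` did not give a number in this assay: compound 2 gives > 100000 nM, which is a limit of the measurement rather than a value. That places compound 2 at the limit of > 100000 nM in this assay, at which 1 of the 2 values shown sits.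

Compound 3 `COc1ccc2[nH]cc(SCC(=O)Nc3ccc(Cl)c(Cl)c3)c2c1` has not yet been measured. It differs from compound 1 by a single change, (methoxy in place of chloro on an aromatic carbon), that is, methoxy in place of chloro on an aromatic carbon. Within the data shown here, no pair of measured compounds shows a comparable change, so the size of this step cannot be read from data. The step of a 1.4-fold higher number from compound 1 to compound 3 (0.15 log units; within the scatter) is expected to be small, toward more compound being tolerated, and may not rise above the usual scatter. For compound 3 the estimate in this assay is 60000 nM, with a range from 25000 nM to 100000 nM.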

Compound 3, half-maximal cytotoxic concentration: 61800 nM
Compound 3: middle estimate off by 1.0-fold (0.01 log units), on the low side, and the stated range covers the measured number.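

On the shared core, methoxy in place of chloro on an aromatic carbon gives a 1.4-fold higher number from compound 1 to compound 3 (0.16 log units; within the scatter) in this assay. Among these compounds, this is the first single change that can be sized here, and it shows that compound 1 and compound 3 cannot be told apart in this assay, even though one heavy atom leaves, two enter, and a hydrogen-bond acceptor comes in at this position. Nothing shown accounts for the size of this step.

On these data alone, whether an amine or a carboxylic acid at the same position would stay equally close to compound 1 remains open. One step also cannot show whether the same exchange of chloro for methoxy would behave in the same way at another place on the molecule.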